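A few compounds are considered here, and "the series" means these few. Any claim that something is new, unique, unknown or untested is made for them only; others in the source may bear on it.

Compound 1, `COc1ccc([C@@H]2C/C(=N/OCc3cn(-c4ccc(Cl)cc4C)nn3)c3cc(CC=C(C)C)c(OC)cc3O2)cc1`, gives 20% in a functional assay on HCT-116 cells (Homo sapiens) for inhibition, read by sulforhodamine B assay, with a stated time of 48 h, tested at 50 uM; a lower number here means less inhibition of growth, a higher number more inhibition of growth at the concentration tested. Compound 2, `CCOc1ccc([C@@H]2CC(=O)c3cc(CC=C(C)C)c(OC)cc3O2)cc1`, gives 65% in this assay. Compound 3, `COc1cc2c(cc1CC=C(C)C)C(=O)C[C@@H](c1ccc(Oc3cccc([N+](=O)[O-])c3)cc1)O2`, gives 46% in this assay.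

Compound 1 stands lowest of the three numbers: its nearest neighbour is compound 3, beyond the scatter above it, and compound 2 lies furthest above it. Within the data shown here, the only step between measured compounds, a number 19 percentage points lower from compound 2 to compound 3 (beyond the scatter), concerns a change on an oxygen on an aromatic ring, not the group on the aromatic nitrogen, so it does not bear on the change in hand. Compound 4, `COc1ccc([C@@H]2C/C(=N/OCc3cn(-c4cc(OC)c(OC)c(OC)c4)nn3)c3cc(CC=C(C)C)c(OC)cc3O2)cc1`, differs from compound 1 by 3,4,5-trimethoxyphenyl in place of 4-chloro-2-methylphenyl on an aromatic nitrogen. Among the measured compounds shown here, with no measured step covering that place, no movement beyond the scatter is expected, and the step of a number 8 percentage points higher from compound 1 to compound 4 (within the scatter) is expected to be small. Compound 4 is therefore estimated at 28%, between 8% and 55%.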

Compound 4, percent growth inhibition at one concentration: 29%
The estimate for compound 4 lay 1 percentage points below the measured number; low and high end bracket the measured number.
By their numbers in this assay, from the lowest: compounds 1 and 4 (each within the scatter of the next); then compound 3; then compound 2.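

In this assay, the change on the aromatic nitrogen gives a number 9 percentage points higher from compound 1 to compound 4 (within the scatter). This position therefore tolerates an exchange of 4-chloro-2-methylphenyl for the larger 3,4,5-trimethoxyphenyl, with its hydrogen-bond acceptors, without a step beyond the scatter. No available evidence accounts for this result.

The compounds shown leave open whether a group other than a substituted phenyl on this nitrogen, such as a longer alkyl chain or a chain ending in an amine or a carboxylic acid, would shift the number beyond the scatter.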